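Halogen swap on the aryl nitrile of a quinoline series

The compounds below may be only part of what the source reports. "The series", "measured", "known", "first", "only" and "open" are said of these compounds alone.

Measured compounds:
compound 1 `Cc1ccc2ccc(-c3cccc(Cl)c3)cc2n1` — 14000 nM
compound 2 `Cc1ccc2ccc(-c3cc(F)cc(C#N)c3)cc2n1` — 0.8 nM

In a functional assay on CHO cells for inhibition of metabotropic glutamate receptor 5 (Rattus norvegicus), read by FLIPR and calcium flux (on this read-out higher numbers stand for weaker inhibition and lower numbers for stronger inhibition), compound 2 gives the lower of the two numbers; compound 1 sits far higher, beyond the scatter. Compound 3 `Cc1ccc2ccc(-c3cc(Cl)cc(C#N)c3)cc2n1` is not yet measured. It differs from compound 2 by chloro in place of fluoro on an aromatic carbon, a chloro in place of fluoro on an aromatic carbon, meta to a cyano group. Going by the values given here, no measured pair isolates this change, so the expected step from compound 2 to compound 3 is small, a 1.9-fold higher number from compound 2 to compound 3 (0.27 log units; within the scatter), within or barely beyond the scatter. Compound 3 is estimated at 1.5 nM, with a range from 0.4 nM to 6 nM.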

Compound 3, half-maximal inhibitory concentration: 1.4 nM
Compound 3: the middle estimate sits 1.1-fold (0.03 log units) above what was measured; measured number inside the range.
By their numbers in this assay, from the lowest: compounds 2 and 3 (each within the scatter of the next); then compound 1.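

In this assay, chloro in place of fluoro on an aromatic carbon, meta to a cyano group, gives a 1.8-fold higher number from compound 2 to compound 3 (0.24 log units; within the scatter) and so leaves the read-out unresolved between these two halogens. The cyano group marks the large difference, with cyano in place of hydrogen on an aromatic carbon giving a 10000-fold lower number from compound 1 to compound 3 (4.00 log units; beyond the scatter) while the chloro stays in place. No measured evidence bears on the cause of either step.

Open, from the compounds shown here alone, is whether this position accepts a methoxy group or an amine as well as a halogen. Also open, going by these compounds, is whether a carboxylic acid could stand in place of the cyano group without losing the low numbers of compound 2 and compound 3.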